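The source may report more compounds than this note shows. Statements on the series, on what has been measured and on what is new or still open speak of the compounds shown alone.

In a functional assay on A549 cells (Homo sapiens) for antiproliferative activity, read by MTT assay, with a stated time of 24 h (a higher number here means a weaker inhibitor, a lower number a stronger inhibitor), compound 1 (`Cc1ccccc1NNC(=O)c1cccc(NS(=O)(=O)c2cnc(O)nc2O)c1`) gives 14200 nM and compound 2 (`O=C(NNc1ccccc1F)c1cccc(NS(=O)(=O)c2cnc(O)nc2O)c1`) gives 11100 nM while compound 3 (`O=C(NNC(=O)c1ccccc1Cl)c1cccc(NS(=O)(=O)c2cnc(O)nc2O)c1`) gives 3740 nM as the lowest of the three numbers. Compound 4 (`O=C(NNC(=O)c1cccc(NS(=O)(=O)c2cnc(O)nc2O)c1)c1cccc(Cl)c1`) is still unmeasured and differs from compound 3 (3-chlorophenyl in place of 2-chlorophenyl on a carbonyl carbon) by having 3-chlorophenyl in place of 2-chlorophenyl on a carbonyl carbon. The nearest measured steps are a 3.8-fold lower number from compound 1 to compound 3 (0.58 log units; beyond the scatter) and a 3.0-fold lower number from compound 2 to compound 3 (0.47 log units; beyond the scatter) which are modest and beyond the scatter, while a 1.3-fold lower number from compound 1 to compound 2 (0.11 log units; within the scatter) stays within it. None of these shifts the chlorine on its ring, so they offer no direct measure of this change. In this assay no step beyond the scatter is therefore expected, in either direction. The expected step is a 1.1-fold higher number from compound 3 to compound 4 (0.03 log units; within the scatter) as an estimate. For compound 4 the estimated value is 4000 nM with an expected range of 1600 nM to 10000 nM around it.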

Compound 4, half-maximal inhibitory concentration: 6000 nM
For compound 4 the middle estimate is 1.5-fold (0.18 log units) below the measured one; low and high end bracket the measured number.
By their numbers in this assay, from the lowest: compounds 3, 4, 2 and 1 (each within the scatter of the next, the first and the last beyond it).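

In this assay, moving the chlorine from 2-chlorophenyl to 3-chlorophenyl on the carbonyl carbon gives a 1.6-fold higher number from compound 3 to compound 4 (0.21 log units; within the scatter), so this first direct test of the chlorine's place shows no clear effect. Replacing 2-methylphenyl with (3-chlorophenyl)carbonyl gives a 2.4-fold lower number from compound 1 to compound 4 (0.37 log units; beyond the scatter), which lies beyond the scatter, while replacing 2-fluorophenyl with it gives a 1.9-fold lower number from compound 2 to compound 4 (0.27 log units; within the scatter), which stays within it. No evidence available here explains these numbers. As far as these compounds go, whether an amine or a carboxylic acid in place of the chlorine would move the number beyond the scatter remains open.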